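The source may hold more compounds than are shown below. What is called first, only, known or untested is meant among the compounds shown, and "the series" means these compounds.

Compound 1 `Cc1ccccc1-n1nc(C)c2c1NC(=O)[C@H](C)S[C@@H]2c1ccc(-c2ccoc2)cc1` gives 3500 nM in an assay on isolated protein for agonist activity at Bile acid receptor (Homo sapiens), read by AlphaScreen, with a stated time of 30 min; on this read-out higher numbers stand for an effect only at larger amounts of compound and lower numbers for an effect already at smaller amounts. Compound 2 `CCOc1cccc(-c2ccc([C@H]3S[C@@H](C)C(=O)Nc4c3c(C)nn4-c3ccccc3C)cc2)c1` gives 3500 nM in this assay.

On these numbers compound 2 stands level with compound 1 at the digits printed. Within the data shown here, the one measured step bearing on the new change is no change at the digits printed from compound 1 to compound 2 (within the scatter), in which a furan-3-yl was replaced by a 3-ethoxyphenyl on the same aromatic carbon and the read-out did not move beyond the scatter. Compound 3 `Cc1ccccc1-n1nc(C)c2c1NC(=O)[C@H](C)S[C@@H]2c1ccc(-c2ccco2)cc1` differs from compound 2 by furan-2-yl in place of 3-ethoxyphenyl on an aromatic carbon. That earlier step suggests this aromatic carbon tolerates both a small five-membered ring and a larger six-membered one without a change in this assay, so the step of no change at the digits printed from compound 2 to compound 3 (within the scatter) is expected to be none beyond the scatter, because no change at the digits printed from compound 1 to compound 2 (within the scatter) showed no change for the related swap. Compound 3 is therefore estimated at 3500 nM in this assay, expected within 1200 nM to 10000 nM.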

Compound 3, half-maximal effective concentration: 3600 nM
For compound 3 the middle estimate is 1.0-fold (0.01 log units) below the measured one, within the range that was stated.
By their numbers in this assay, from the lowest: compounds 1, 2 and 3 (each within the scatter of the next).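

In this assay, the step to the smaller ring, a 1.0-fold higher number from compound 2 to compound 3 (0.01 log units; within the scatter), adds a second furan to the comparison with 3-ethoxyphenyl, and again the number stays within the scatter. The new information is in the other step, a 1.0-fold higher number from compound 1 to compound 3 (0.01 log units; within the scatter): moving the attachment point from furan-3-yl to furan-2-yl on this aromatic carbon, para to a large group, also leaves the read-out within the scatter. No evidence is available to explain why these three compounds read alike.

On these data alone, all three groups are aromatic rings that carry oxygen, so it remains open whether an amine, a carboxylic acid or a plain alkyl chain on this carbon would read the same. As far as these compounds go, it also remains open whether any group here can bring the number down.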